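Two Chlorines for One Bromine: Expected Cell Tolerance

The compounds below may be only part of what the source reports. "The series", "measured", "known", "first", "only" and "open" are said of these compounds alone.

Three compounds have been measured in an ADME assay on Vero cells (Chlorocebus sabaeus) for cytotoxicity, read by MTT assay, with a stated time of 72 h; a lower number here means that less compound is tolerated, a higher number that more compound is tolerated:

compound 1 `Fc1ccc([C@@H]2C[C@@H]3Cc4ccc5ccccc5c4N2O3)cc1`: > 300000 nM
compound 2 `Clc1ccc([C@@H]2C[C@@H]3Cc4ccc5ccccc5c4N2O3)cc1`: 287000 nM
compound 3 `Brc1cccc([C@@H]2C[C@@H]3Cc4ccc5ccccc5c4N2O3)c1`: > 250000 nM

For compound 3 this assay gave only a limit, not a number, as shown by the limit of > 250000 nM in this assay, at which 1 of the 3 values shown sits. For compound 1 the reading is also a limit, shown by the limit of > 300000 nM in this assay, at which 1 of the 3 values shown sits. Among the measured compounds shown here, compound 2 is the only one with a measured number. The step of an at least 1.0-fold lower number from compound 1 to compound 2 (0.01 log units; that floor lies within the scatter) lies within the scatter. The steps a step that the two limits leave unreadable from compound 1 to compound 3 and a step that the limit leaves unreadable from compound 2 to compound 3 cannot be sized, since limits stand at one end.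

Compound 4 `Clc1ccc([C@@H]2C[C@@H]3Cc4ccc5ccccc5c4N2O3)c(Cl)c1` differs from compound 3 by 2,4-dichlorophenyl in place of 3-bromophenyl on a saturated ring carbon. Every measured halogen exchange so far left tolerance unchanged or unreadable, so no step beyond the scatter is expected, a number no higher from compound 3 to compound 4 (the limit leaves the size open). Compound 4 is therefore estimated at 250000 nM, within 100000 nM to 400000 nM.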

Compound 4, half-maximal cytotoxic concentration: 55000 nM
For compound 4 the middle estimate is 4.5-fold (0.66 log units) above the measured one; measured number outside the range, below it.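

Among the compounds shown here, putting chloro in place of hydrogen on the aromatic ring of compound 2 gives a 5.2-fold lower number from compound 2 to compound 4 (0.72 log units; beyond the scatter), so the aryl group on this saturated ring carbon can change tolerance in this assay, which no earlier readable step showed. Two further steps point the same way, though each is only a floor: an at least 4.5-fold lower number from compound 3 to compound 4 (0.65 log units; beyond the scatter) and an at least 5.4-fold lower number from compound 1 to compound 4 (0.73 log units; beyond the scatter). Nothing shown explains why tolerance falls.

Open, as far as these compounds go, is whether a methoxy group or an amine in place of the added chloro would lower tolerance too.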